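Replacing an aryl with a benzyl group on a piperazine

A few compounds are considered here, and "the series" means these few. Any claim that something is new, unique, unknown or untested is made for them only; others in the source may bear on it.

Of the compounds shown here, three of a shared core have been measured in a functional assay on cells (T-cell, Homo sapiens) for inhibition; on this read-out lower numbers stand for stronger inhibition and higher numbers for weaker inhibition. Compound 1 `COc1ccc(-c2cnc3nc(N)nc(N4CCC(C)CC4)c3n2)cc1OC` gives 800 nM, compound 3 `CCOc1nc(N)nc2ncc(-c3cccc(OC)c3)nc12` gives 8300 nM, and compound 2 `COc1ccc(-c2cnc3nc(N)nc(N4CCN(c5ccc(C)cc5)CC4)c3n2)cc1OC` gives 300 nM, the lowest of the three numbers, beyond the scatter from both of the others. Compound 4 `COc1ccc(-c2cnc3nc(N)nc(N4CCN(Cc5ccc(C(C)(C)C)cc5)CC4)c3n2)cc1OC` has not yet been measured; it differs from compound 2 in one place: 4-(tert-butyl)benzyl in place of 4-methylphenyl on an amine nitrogen in a ring. For the measured compounds named here, with no measured pair showing this kind of change, there is no step to lean on. The step from compound 2 to compound 4 is expected to be small, a 2.0-fold higher number from compound 2 to compound 4 (0.30 log units; within the scatter), towards a slightly higher number, possibly within the scatter. Compound 4 is therefore estimated to give 600 nM in this assay, in the range 150 nM to 2500 nM.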

Compound 4, half-maximal inhibitory concentration: 4300 nM
Compound 4: the middle estimate sits 7.2-fold (0.86 log units) below what was measured; the measured number lies above the stated range.
By their numbers in this assay, from the lowest: compound 2; then compound 1; then compounds 4 and 3 (each within the scatter of the next).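

This position on an amine nitrogen in a ring proves sensitive: in this assay, 4-(tert-butyl)benzyl in place of 4-methylphenyl gives a 14-fold higher number from compound 2 to compound 4 (1.16 log units; beyond the scatter), a large step, although both groups carry one six-membered aromatic ring of carbon only and neither has hydrogen-bond donors or acceptors. No measurement at hand bears on why the step is so large.

The change alters both the link to the ring and the group at its far end, and the compounds shown do not separate the two. On these data alone, whether a plain benzyl or a 4-(tert-butyl)phenyl group would stay close to compound 2 remains open.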